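Chloro in Place of Methyl on an Aromatic Carbon

A few compounds are considered here, and "the series" means these few. Any claim that something is new, unique, unknown or untested is made for them only; others in the source may bear on it.

Compound 1 `CCCn1c(=O)[nH]c2nc(-c3ccc(S(=O)(=O)N4CCN(c5ccc(Br)cc5)CC4)cc3)[nH]c2c1=O` gives 0.0835 nM in an assay on CHO cells for displacement of a labelled ligand from adenosine receptor A2b (Homo sapiens), read by scintillation counting, with a stated time of 75 min, in the presence of a further agent that is not named here; a higher number here means a weaker inhibitor, a lower number a stronger inhibitor.
Compound 2 `CCCn1c(=O)[nH]c2nc(-c3ccc(S(=O)(=O)N4CCN(c5ccccc5C)CC4)cc3)[nH]c2c1=O` gives 0.432 nM in this assay.

Compound 2 has the higher of these two numbers, so it is the weaker inhibitor; the step of a 5.2-fold higher number from compound 1 to compound 2 (0.71 log units; beyond the scatter) lies beyond the scatter. Compound 3 `CCCn1c(=O)[nH]c2nc(-c3ccc(S(=O)(=O)N4CCN(c5ccccc5Cl)CC4)cc3)[nH]c2c1=O` differs from compound 2 by chloro in place of methyl on an aromatic carbon. Among the measured compounds shown here, only one measured step exists, and it swaps the group and its place at once, so it bears on this change only loosely. A small move toward a lower number in this assay is expected for compound 3 because compound 1 with its bromo gives 0.0835 nM, and chloro is also a halogen. The estimated value for compound 3 is 0.3 nM, between 0.1 nM and 0.9 nM, an expected step of a 1.4-fold lower number from compound 2 to compound 3 (0.16 log units; within the scatter).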

Compound 3, inhibition constant: 0.403 nM
For compound 3 the middle estimate is 1.3-fold (0.13 log units) below the measured one, and the stated range covers the measured number.
By their numbers in this assay, from the lowest: compound 1; then compounds 3 and 2 (each within the scatter of the next).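

Chloro and methyl on this aromatic carbon, ortho to a large group, cannot be told apart in this assay: the swap gives a 1.1-fold lower number from compound 2 to compound 3 (0.03 log units; within the scatter). Having a halogen here therefore does not bring the number to that of compound 1, as 2-chlorophenyl still shows a 4.8-fold higher number from compound 1 to compound 3 (0.68 log units; beyond the scatter). Nothing measured here explains why chloro and methyl match.

From the compounds shown here alone, that last step changes both the halogen and its place on the ring, so the contribution of each stays open. A methoxy group or a nitrile on this carbon could show whether other groups also give a similar number.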